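The compounds below may be only part of what the source reports. "The series", "measured", "known", "first", "only" and "open" are said of these compounds alone.

Measured so far:
Compound 1, `Fc1ccc(C(SCCNC2CCN(Cc3ccc(C(F)(F)F)cc3)CC2)c2ccc(F)cc2)cc1`: 186 nM in an assay on membranes from Cortex for displacement of a labelled ligand from Sigma non-opioid intracellular receptor 1 (Cavia porcellus), read by scintillation counting, with a stated time of 120 min; on this read-out lower numbers stand for stronger inhibition and higher numbers for weaker inhibition
Compound 2, `Fc1ccc(C(SCCNC2CCN(Cc3cc4ccccc4[nH]3)CC2)c2ccc(F)cc2)cc1`: 205 nM in this assay

Compound 2 holds the highest of these two numbers, yet the step of a 1.1-fold higher number from compound 1 to compound 2 (0.04 log units; within the scatter) is within the scatter, so the two compounds cannot be told apart. Compound 3, `CC(C)(C)CN1CCC(NCCSC(c2ccc(F)cc2)c2ccc(F)cc2)CC1`, differs from compound 2 by tert-butyl in place of 1H-indol-2-yl on a saturated chain carbon bound to an amine nitrogen in a ring. For the measured compounds named here, only the step of a 1.1-fold higher number from compound 1 to compound 2 (0.04 log units; within the scatter) bears on this position, and it kept a ring in place, so no measured step shows what removing the ring does. The step to compound 3 is therefore expected to be a 1.6-fold higher number from compound 2 to compound 3 (0.19 log units; within the scatter), a mild weakening at most. Compound 3 is estimated at 320 nM, within 120 nM to 850 nM.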

Compound 3, inhibition constant: 315 nM
Beside the measured number, compound 3's estimate is 1.0-fold (0.01 log units) above it, within the range that was stated.
By their numbers in this assay, from the lowest: compounds 1, 2 and 3 (each within the scatter of the next).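

For the compounds shown here, until now, the only step at this position replaced one ring-bearing group with another. Tert-butyl, which has no ring, gives a 1.5-fold higher number from compound 2 to compound 3 (0.19 log units; within the scatter) and a 1.7-fold higher number from compound 1 to compound 3 (0.23 log units; within the scatter) in this assay, so an aromatic ring on this saturated chain carbon is not shown to matter for this read-out. Nothing available explains this result. Still open, on these data alone, is what a methyl group, or a longer chain ending in an amine or a carboxylic acid, would do in the same place.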